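This account rests on a few compounds, and the source may have more. Where it says the series, first, only, none or still open, it means among the compounds named here.

Compound 2 `Cc1cc(C)cc(Cc2ccc3c(NCCCNCc4ccco4)ccnc3c2)c1` gives 6270 nM in an ADME assay on HepG2 cells (Homo sapiens) for cytotoxicity, read by luminescence, CellTiter-Glo and ATP content, with a stated time of 72 h (on this read-out higher numbers stand for an effect only at larger amounts of compound and lower numbers for an effect already at smaller amounts), the highest of the three numbers recorded so far. Compound 1 `COc1ccc(F)cc1CNCCCNc1ccnc2cc(Cc3cc(C)cc(C)c3)ccc12` gives 940 nM in this assay, and compound 3 `COc1cccc(CNCCCNc2ccnc3cc(CC4CCCCC4)ccc23)c1O` gives 970 nM. Among the compounds with values here, the single measured step that changes one place, a 6.7-fold higher number from compound 1 to compound 2 (0.82 log units; beyond the scatter), concerns the group on the saturated chain carbon bound to an amine nitrogen, and that part of compound 2 is carried unchanged into compound 4 `Clc1ccc(Oc2ccc3c(NCCCNCc4ccco4)ccnc3c2)cc1`. The change leading to compound 4 lies elsewhere: 4-chlorophenoxy in place of 3,5-dimethylbenzyl on an aromatic carbon. Within the data shown here, no measured step bears on this exchange. Compound 3 does carry a different group at that aromatic carbon, but it also differs from compound 2 at the amine nitrogen, so its value cannot be assigned to either change. Among the measured compounds shown here, with no guiding step, the analyst expects the number for compound 4 to remain near that of compound 2, allowing a wide range in either direction, which is expressed as a 1.6-fold lower number from compound 2 to compound 4 (0.20 log units; within the scatter). The estimate for compound 4 in this assay is 4000 nM, expected between 1300 nM and 12000 nM.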

Compound 4, half-maximal effective concentration: 7800 nM
Beside the measured number, compound 4's estimate is 2.0-fold (0.29 log units) below it, within the range that was stated.
By their numbers in this assay, from the lowest: compounds 1 and 3 (each within the scatter of the next); then compounds 2 and 4 (each within the scatter of the next).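

In this assay, the exchange at this aromatic carbon of the shared core now has a measured step, a 1.2-fold higher number from compound 2 to compound 4 (0.09 log units; within the scatter), with the furan-2-yl group on the chain held fixed. Within the data shown here, at this position, 4-chlorophenoxy in place of 3,5-dimethylbenzyl therefore leaves the number within the scatter, whereas the one earlier step, at the group on the chain, lay beyond it. No measurement at hand offers an explanation for this result.

On these data alone, whether the exchange reads the same with the 5-fluoro-2-methoxyphenyl group on the chain, as carried by compound 1, stays open, as the step rests on a single pair of compounds. The compounds shown also leave open how an amine or a carboxylic acid at this aromatic carbon would read in this assay.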